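A Further Trifluoromethyl on Compound 2

The compounds below may be only part of what the source reports. "The series", "measured", "known", "first", "only" and "open" are said of these compounds alone.

In a functional assay on MDA-MB-468 cells (Homo sapiens) for antiproliferative activity, read by sulforhodamine B assay, with a stated time of 72 h (a lower number here means a stronger inhibitor, a higher number a weaker inhibitor), compound 1 `FC(F)(F)c1cccc(/C=C\c2cc3ccccc3nc2Cl)c1` gives 3700 nM and compound 2 `COc1ccc2nc(Cl)c(/C=C\c3cccc(C(F)(F)F)c3)cc2c1` gives 3910 nM. Among the compounds with values here, these two numbers lie within the scatter of each other, so compound 2 stands level with the only other measured compound. Compound 3 `COc1ccc2nc(Cl)c(/C=C\c3cc(C(F)(F)F)cc(C(F)(F)F)c3)cc2c1` keeps the rest of compound 2 and differs in one place: trifluoromethyl in place of hydrogen on an aromatic carbon. This is trifluoromethyl in place of hydrogen on an aromatic carbon, meta to a large group and meta to a trifluoromethyl group. Within the data shown here, the only measured step, a 1.1-fold higher number from compound 1 to compound 2 (0.02 log units; within the scatter), is methoxy in place of hydrogen, a different change on another part of the molecule. It bears on the new change only indirectly, and it stayed within the scatter. Among the measured compounds shown here, no measured pair shows what adding a trifluoromethyl group does, so the data support no direction and the range must stay wide. In this assay, no step beyond the scatter is therefore expected, and the estimated step is a 1.1-fold lower number from compound 2 to compound 3 (0.05 log units; within the scatter). Compound 3 is expected to give 3500 nM, with an estimated range of 1300 nM to 9000 nM.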

Compound 3, half-maximal inhibitory concentration: 5790 nM
Compound 3: the middle estimate sits 1.7-fold (0.22 log units) below what was measured; measured number inside the range.
By their numbers in this assay, from the lowest: compounds 1, 2 and 3 (each within the scatter of the next).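

Placing a trifluoromethyl group on this aromatic carbon, meta to a large group and meta to a trifluoromethyl group, gives the first measured step at this part of the molecule, and in this assay that step is a 1.5-fold higher number from compound 2 to compound 3 (0.17 log units; within the scatter). The ring of compound 3 therefore carries trifluoromethyl groups at both of these places, and the added four heavy atoms leave the number within the scatter of the number for compound 2, so this single change does not separate the two compounds in this assay. Nothing shown gives a reason for this result, and no measurement of any property of these compounds bears on it.

As far as these compounds go, whether a smaller or a very different group on the same aromatic carbon, such as an amine, a carboxylic acid or a longer chain, would give a step beyond the scatter remains open. Also open, from the compounds shown here alone, is whether the same trifluoromethyl change would give a similar step on the core of compound 1, which has hydrogen where compound 2 has methoxy.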